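The source may hold more compounds than are shown below. What is called first, only, known or untested is meant among the compounds shown, and "the series" means these compounds.

Measured so far:
compound 1 `CCCCCCCCCCCCNc1nc2ccccc2nc1Oc1ccc(C(=O)N[C@@H](C)C(=O)O)cc1` gives 4110 nM in a functional assay on MCF7 cells (Homo sapiens) for antiproliferative activity, read by MTT assay, with a stated time of 48 h; on this read-out lower numbers stand for stronger inhibition and higher numbers for weaker inhibition
compound 2 `CCCCCCCCCCCCNc1nc2ccccc2nc1Oc1ccc(C(=O)N[C@H](C(=O)O)[C@H](C)CC)cc1` gives 30400 nM in this assay
compound 3 `C[C@H](NC(=O)c1ccc(Oc2nc3ccccc3nc2NC(C)(C)C)cc1)C(=O)O` gives 29400 nM in this assay

Compound 3 differs from compound 1 in its core by tert-butyl in place of dodecyl on a nitrogen on an aromatic ring, and that difference alone gave a 7.2-fold higher number from compound 1 to compound 3 (0.85 log units; beyond the scatter). Compound 4 `CC[C@@H](C)[C@H](NC(=O)c1ccc(Oc2nc3ccccc3nc2NC(C)(C)C)cc1)C(=O)O` has not yet been measured. It carries the core of compound 3 together with the change (sec-butyl in place of methyl on a saturated chain carbon bound to an amide-type nitrogen and a carbonyl carbon). The same change has already been made once, on the core of compound 1: compound 2 differs from compound 1 by sec-butyl in place of methyl on a saturated chain carbon bound to an amide-type nitrogen and a carbonyl carbon, and that step gave a 7.4-fold higher number from compound 1 to compound 2 (0.87 log units; beyond the scatter). The place of the change is the same in both pairs, so the change from compound 3 to compound 4 is the same change, made on a core that already gives a higher number. Among the compounds with values here, since only one example of this change is known, and compound 3 and compound 2 lie within the scatter of each other, the step for compound 4 is expected to be of about the same size, a 5.1-fold higher number from compound 3 to compound 4 (0.71 log units; beyond the scatter), because the earlier step was a 7.4-fold higher number from compound 1 to compound 2 (0.87 log units; beyond the scatter). Compound 4 is therefore estimated at 150000 nM, with a likely range from 40000 nM to 400000 nM, and it is possible that this assay reports only a limit for it.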

Compound 4, half-maximal inhibitory concentration: 11400 nM
Compound 4: middle estimate off by 13-fold (1.12 log units), on the high side, outside the stated range (below it).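

In this assay, sec-butyl in place of methyl on the core of compound 3 gave a 2.6-fold lower number from compound 3 to compound 4 (0.41 log units; beyond the scatter), so this step runs in the opposite direction to the one on the core of compound 1: the same change on two cores in this assay, a 7.4-fold higher number (0.87 log units; beyond the scatter) from compound 1 to compound 2 and a 2.6-fold lower number (0.41 log units; beyond the scatter) from compound 3 to compound 4, 19-fold (1.28 log units) apart, beyond the scatter of two such steps. Read along the other edge of the same four compounds, tert-butyl in place of dodecyl on the nitrogen gave a 2.7-fold lower number from compound 2 to compound 4 (0.43 log units; beyond the scatter) when sec-butyl was already present, and this too differs from the step seen with methyl: the same change on two cores in this assay, a 7.2-fold higher number (0.85 log units; beyond the scatter) from compound 1 to compound 3 and a 2.7-fold lower number (0.43 log units; beyond the scatter) from compound 2 to compound 4, 19-fold (1.28 log units) apart, beyond the scatter of two such steps. In these four compounds, then, the outcome of each change depends on the group at the other place, so a step measured on one core cannot simply be carried to another, although the numbers do not show why this happens or which way a further core would go.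

On these data alone, it remains open whether the reversal would hold with an isopropyl or benzyl group on the side chain, or with a hexyl chain on the nitrogen. As far as these compounds go, how a methyl ester in place of the carboxylic acid would behave also remains open.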